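The compounds below may be only part of what the source reports. "The series", "measured", "known", "first", "only" and "open" are said of these compounds alone.

Measured in a functional assay on MDA-MB-231 cells (Homo sapiens) for antiproliferative activity, read by MTT assay, with a stated time of 72 h; on this read-out higher numbers stand for weaker inhibition and lower numbers for stronger inhibition:
Compound 1 `CC1=CC[C@H]2[C@H](CC[C@]2(C)O)C(C)(C)[C@@H]1CC[C@H]1[C@]2(C)CC[C@H](OC(=O)c3ccc(C)cc3)C(C)(C)O[C@H]2CC[C@@]1(C)O`: 33400 nM
Compound 2 `CC1=CC[C@H]2[C@H](CC[C@]2(C)O)C(C)(C)[C@@H]1CC[C@H]1[C@]2(C)CC[C@H](OC(=O)c3ccc(Cl)c(Cl)c3)C(C)(C)O[C@H]2CC[C@@]1(C)O`: 8100 nM
Compound 3 `CC1=CC[C@H]2[C@H](CC[C@]2(C)O)C(C)(C)[C@@H]1CC[C@H]1[C@]2(C)CC[C@H](OC(=O)c3ccccc3[N+](=O)[O-])C(C)(C)O[C@H]2CC[C@@]1(C)O`: 38700 nM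

These three compounds share one core and differ only in the group on a carbonyl carbon. Compound 3, which carries 2-nitrophenyl, cannot be told apart from compound 1, as the step of a 1.2-fold higher number from compound 1 to compound 3 (0.06 log units; within the scatter) shows. Both sit well above compound 2, and the step of a 4.8-fold higher number from compound 2 to compound 3 (0.68 log units; beyond the scatter) marks that gap for compound 3.

Compound 4 `CC1=CC[C@H]2[C@H](CC[C@]2(C)O)C(C)(C)[C@@H]1CC[C@H]1[C@]2(C)CC[C@H](OC(=O)c3ccc([N+](=O)[O-])o3)C(C)(C)O[C@H]2CC[C@@]1(C)O` keeps a nitro group but changes the ring that carries it: 5-nitrofuran-2-yl in place of 2-nitrophenyl on a carbonyl carbon. Among the compounds with values here, no measured step tests such a ring change, since all three measured compounds carry a six-membered aromatic ring of carbon only, so the comparison is indirect. The modest steps, a 4.1-fold lower number from compound 1 to compound 2 (0.62 log units; beyond the scatter) and a 4.8-fold higher number from compound 2 to compound 3 (0.68 log units; beyond the scatter), both involve the 3,4-dichlorophenyl group of compound 2, which compound 4 does not have. The remaining guide is a 1.2-fold higher number from compound 1 to compound 3 (0.06 log units; within the scatter), which suggests that leaving that group out keeps the number high. No step beyond the scatter is therefore expected in this assay, though a modest drop cannot be excluded. The expected change is a 1.5-fold lower number from compound 3 to compound 4 (0.19 log units; within the scatter). For compound 4 the estimate is 25000 nM, with an expected range of 9000 nM to 55000 nM.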

Compound 4, half-maximal inhibitory concentration: 11100 nM
Estimate against measurement, compound 4: 2.3-fold (0.35 log units) above; the measured number falls inside the stated range.
By their numbers in this assay, from the lowest: compounds 2 and 4 (each within the scatter of the next); then compounds 1 and 3 (each within the scatter of the next).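

On the carbonyl carbon of the shared core, a nitro group does not by itself set the number in this assay, since replacing 2-nitrophenyl with 5-nitrofuran-2-yl gives a clear change (a 3.5-fold lower number from compound 3 to compound 4 (0.54 log units; beyond the scatter)). Until now, only the 3,4-dichlorophenyl group had stood apart from the others, but 5-nitrofuran-2-yl also separates from 4-methylphenyl (a 3.0-fold lower number from compound 1 to compound 4 (0.48 log units; beyond the scatter)) and cannot be told apart from 3,4-dichlorophenyl (a 1.4-fold higher number from compound 2 to compound 4 (0.14 log units; within the scatter)), so two quite different groups now share the lower level. No measurement offered here accounts for this shift.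

The compounds shown leave open whether the lower number belongs to the five-membered ring, to the nitro group on that ring, or to the two together. A plain furan-2-yl group would test the ring without the nitro group, and 4-nitrophenyl would show whether moving the nitro group on the six-membered ring changes the number without any change of ring.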